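The source may hold more compounds than are shown below. What is called first, only, known or untested is meant among the compounds shown, and "the series" means these compounds.

The compounds share one core and differ at one side chain, on a saturated chain carbon bound to a saturated ring carbon. In a functional assay on P388 cells (Mus musculus) for cytotoxicity (a lower number here means a stronger inhibitor, a higher number a weaker inhibitor), compound 1 `COc1ccc(C[C@H]2C(=O)N[C@@H](C)C(=O)N(C)[C@H]3Cc4ccc(cc4)Oc4cc(ccc4OC)C[C@@H](C(=O)N[C@H](C)C(=O)N[C@@H](CSC(C)=O)C(=O)N2C)N(C)C3=O)cc1` gives 9.77 nM, compound 2 `COc1ccc(C[C@H]2C(=O)N[C@@H](C)C(=O)N(C)[C@H]3Cc4ccc(cc4)Oc4cc(ccc4OC)C[C@@H](C(=O)N[C@H](C)C(=O)N[C@@H](CCCO)C(=O)N2C)N(C)C3=O)cc1` gives 174 nM and compound 3 `COc1ccc(C[C@H]2C(=O)N[C@@H](C)C(=O)N(C)[C@H]3Cc4ccc(cc4)Oc4cc(ccc4OC)C[C@@H](C(=O)N[C@H](C)C(=O)N[C@@H](CC=O)C(=O)N2C)N(C)C3=O)cc1` gives 33.9 nM. Compound 3 therefore holds the second highest of the three numbers, with a 3.5-fold higher number from compound 1 to compound 3 (0.54 log units; beyond the scatter) and a 5.1-fold lower number from compound 2 to compound 3 (0.71 log units; beyond the scatter).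

Compound 4 `CCC[C@@H]1NC(=O)[C@@H](C)NC(=O)[C@@H]2Cc3ccc(OC)c(c3)Oc3ccc(cc3)C[C@@H](C(=O)N2C)N(C)C(=O)[C@H](C)NC(=O)[C@H](Cc2ccc(OC)cc2)N(C)C1=O` carries ethyl in place of the formyl of compound 3: ethyl in place of formyl on a saturated chain carbon bound to a saturated ring carbon. The same difference reads formylmethyl to propyl.

Going by the values given here, no measured step makes this exact change. The closest guide is a 5.1-fold lower number from compound 2 to compound 3 (0.71 log units; beyond the scatter), which joins formyl and 2-hydroxyethyl at this place, and ethyl resembles 2-hydroxyethyl more in name than it resembles formyl. The largest step here, an 18-fold higher number from compound 1 to compound 2 (1.25 log units; beyond the scatter), shows how far this side chain can move the number. A modest rise in this assay is expected, read backwards from the step between compound 2 and compound 3 and no larger than it.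

The expected step is a 2.1-fold higher number from compound 3 to compound 4 (0.31 log units; beyond the scatter). The estimate for compound 4 is 70 nM, with an expected range of 25 nM to 200 nM.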

Compound 4, half-maximal inhibitory concentration: 13.8 nM
Compound 4: middle estimate off by 5.1-fold (0.71 log units), on the high side; measured number outside the range, below it.
By their numbers in this assay, from the lowest: compounds 1 and 4 (each within the scatter of the next); then compound 3; then compound 2.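

In this assay, ethyl in place of formyl gives a 2.5-fold lower number from compound 3 to compound 4 (0.39 log units; beyond the scatter), so at this place a chain with no oxygen is not weaker than the formyl-bearing chain. Removing only the hydroxy, three bonds along the chain from a saturated ring carbon, gives a 13-fold lower number from compound 2 to compound 4 (1.10 log units; beyond the scatter), so this single atom accounts for a large step and the weak number belongs to the hydroxy rather than to chain length. Ethyl in place of acetylsulfanyl gives a 1.4-fold higher number from compound 1 to compound 4 (0.15 log units; within the scatter), so neither the sulfur nor the carbonyl of acetylsulfanyl is needed to reach the lowest numbers in this set.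

From the compounds shown here alone, an amine or a carboxylic acid on this chain, or a chain longer than propyl, remains open. No measurement shown here bears on the reason for these steps.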